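Amide nitrogen substituent change, agonist efficacy working notes

A few compounds are considered here, and "the series" means these few. Any claim that something is new, unique, unknown or untested is made for them only; others in the source may bear on it.

Measured so far:
compound 1 `CC(C)c1onc(-c2c(Cl)cccc2Cl)c1COc1ccc(C(=O)N(Cc2ccccc2)c2ccc(C(=O)O)cc2)c(Cl)c1`: 41%
compound 2 `CC(C)c1onc(-c2c(Cl)cccc2Cl)c1COc1ccc(C(=O)N(c2cccc(C(=O)O)c2)c2cccc3ccccc23)c(Cl)c1`: 28%
compound 3 `CC(C)c1onc(-c2c(Cl)cccc2Cl)c1COc1ccc(N(C(=O)c2cccc(C(=O)O)c2)c2cccc3ccccc23)c(Cl)c1`: 35%

All three were read in a functional assay on HEK293 cells for agonist activity at Bile acid receptor (Homo sapiens), read by a luciferase reporter; on this read-out higher numbers stand for larger maximal responses and lower numbers for smaller maximal responses. Compound 2 gives the lowest of the three numbers; compound 3 stands within the scatter of it, while compound 1 stands beyond it. Compound 4 `CCCCN(C(=O)c1ccc(OCc2c(-c3c(Cl)cccc3Cl)noc2C(C)C)cc1Cl)c1cccc(C(=O)O)c1` is not yet measured. It differs from compound 2 in one place: butyl in place of naphthalen-1-yl on an amide-type nitrogen. Among the compounds with values here, no measured pair shows this change, and compound 1 differs from compound 2 in more than one place, so no step can be borrowed. Compound 4 is expected to give 36%, within a range of 18% to 58%. The expected step of a number 8 percentage points higher from compound 2 to compound 4 (within the scatter) would be upward but hardly beyond the scatter, and a flat outcome is equally plausible.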

Compound 4, largest response reached (reported as efficacy), in percent of the reference or control that the assay uses: 43%
For compound 4 the middle estimate is 7 percentage points below the measured one; low and high end bracket the measured number.
By their numbers in this assay, from the lowest: compounds 2, 3, 1 and 4 (each within the scatter of the next, the first and the last beyond it).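

In this assay butyl in place of naphthalen-1-yl gives a number 15 percentage points higher from compound 2 to compound 4 (beyond the scatter) as the first step read on this amide-type nitrogen. The two aromatic rings of naphthalen-1-yl are therefore not required for the response here, and a chain with no ring gives the larger number. No measurement shown accounts for this step.

From the compounds shown here alone, whether chain length matters remains open, as a single chain cannot show this. Propyl, hexyl or cyclohexyl on this nitrogen would separate the length of the chain from the loss of the aromatic rings.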